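Swapping an Acetylphenyl Arm for Indolyl: Cytotoxicity Outlook

The compounds below may be only part of what the source reports. "The series", "measured", "known", "first", "only" and "open" are said of these compounds alone.

In an ADME assay on Raji cells (Homo sapiens) for cytotoxicity, read by CellTiter-Glo and resazurin assay, with a stated time of 72 h (on this read-out lower numbers stand for an effect already at smaller amounts and higher numbers for an effect only at larger amounts of compound), compound 1 `CC(=O)c1cccc(-c2ccc(C(=O)N(Cc3cccc(OCCCCCC(=O)O)c3)C(C)C)cc2)c1` reaches only the assay limit, > 26000 nM. Compound 2 `CC(C)N(Cc1cccc(OCCCCCC(=O)O)c1)C(=O)c1ccc(-c2ccoc2)cc1` likewise stops at the limit in this assay, giving > 26000 nM. Between them the data give a step that the two limits leave unreadable from compound 1 to compound 2, so no size can be read, and the limit of > 26000 nM in this assay, at which 2 of the 2 values shown sit, shows both measured values resting at this ceiling. Compound 3 `CC(C)N(Cc1cccc(OCCCCCC(=O)O)c1)C(=O)c1ccc(-c2ccc3cc[nH]c3c2)cc1` arises from compound 1 through the change (1H-indol-6-yl in place of 3-acetylphenyl on an aromatic carbon). Within the data shown here, no measured step bears on this change. Compound 3 is therefore expected to stay near the limit, at 30000 nM with a range of 8000 nM to 100000 nM. This amounts to an expected step that the limit leaves unreadable from compound 1 to compound 3.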

Compound 3, half-maximal effective concentration: > 26000 nM
Compound 3: a limit, no number; the forecaster's own chance of this, stated with the estimate: 80%; the middle value lies beyond the limit too.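

Among these compounds, compound 1, compound 2 and compound 3 all stop at a limit in this assay, so no step among them can be read: the limit of > 26000 nM in this assay, at which 3 of the 3 values shown sit. The compounds shown leave open whether any group at this position gives a readable value in this assay.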